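Carbamate indoles against monoamine oxidase A: propargyl on nitrogen

A few compounds are considered here, and "the series" means these few. Any claim that something is new, unique, unknown or untested is made for them only; others in the source may bear on it.

Measured so far:
compound 1, `CCN(CC)C(=O)Oc1ccc2[nH]ccc2c1`: 13200 nM
compound 2, `CCN(CC)C(=O)Oc1ccc2cc[nH]c2c1`: 88100 nM

In an assay on isolated protein for inhibition of Amine oxidase [flavin-containing] A (Homo sapiens), read by fluorescence, with stated times of 10 min, 10 s and 20 min (a lower number here means a stronger inhibitor, a higher number a weaker inhibitor), compound 2 gives the highest of the two numbers. Its nearest neighbour, compound 1, sits at a lower number, and the gap between the two lies beyond the usual scatter, so compound 2 is the weaker inhibitor of the pair. The two compounds differ in the shared core itself, not in one group, so no single-change step can be read from them.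

Compound 3, `C#CCn1ccc2ccc(OC(=O)N(CC)CC)cc21`, is compound 2 carrying (propargyl in place of hydrogen on an aromatic nitrogen). Within the data shown here, no measured pair in this set changes anything on an aromatic nitrogen, so the step has no direct precedent here. The expected step from compound 2 to compound 3 is a 2.9-fold lower number from compound 2 to compound 3 (0.47 log units; beyond the scatter), a moderate move toward stronger inhibition, though weakly founded. For compound 3 the estimated value in this assay is 30000 nM, with a range from 5000 nM to 150000 nM.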

Compound 3, half-maximal inhibitory concentration: 51600 nM
Beside the measured number, compound 3's estimate is 1.7-fold (0.24 log units) below it, within the range that was stated.
By their numbers in this assay, from the lowest: compound 1; then compounds 3 and 2 (each within the scatter of the next).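

Propargyl in place of hydrogen on an aromatic nitrogen is the first change at this position among the compounds shown, and in this assay it gives a 1.7-fold lower number from compound 2 to compound 3 (0.23 log units; within the scatter), a step that stays within the scatter. On the core of compound 2, this nitrogen therefore carries propargyl with no change that can be read from the scatter, either toward stronger or toward weaker inhibition. No evidence at hand bears on this result.

Whether propargyl on the aromatic nitrogen of compound 1 would give a similarly small step remains open, as the compounds shown offer no such pair on that core. Also open, on these data alone, is how a methyl group, a saturated propyl chain or a benzyl group at the same nitrogen would read against propargyl.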